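Swapping tert-butyl for cyclopropyl on the side chain

A few compounds are considered here, and "the series" means these few. Any claim that something is new, unique, unknown or untested is made for them only; others in the source may bear on it.

In an ADME assay on Huh-7 cells (Homo sapiens) for cytotoxicity, with a stated time of 72 h (a lower number here means that less compound is tolerated, a higher number that more compound is tolerated), compound 3 `CC(C)(C)CCn1nc(-c2cccs2)c(O)c(C2=NS(=O)(=O)c3cc(NS(C)(=O)=O)ccc3N2)c1=O` gives > 1000 nM as a limit and not a number. Compound 2 `CC(C)CCn1nc(C2CCCCC2)c(O)c(C2=NS(=O)(=O)c3cc(NS(C)(=O)=O)ccc3N2)c1=O` gives > 1000 nM which is also a limit. Compound 1 `CC(C)CCn1nc(-c2cncs2)c(O)c(C2=NS(=O)(=O)c3cc(NS(C)(=O)=O)ccc3N2)c1=O` gives > 33000 nM and this too is a limit.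

Compound 4 `CS(=O)(=O)Nc1ccc2c(c1)S(=O)(=O)N=C(c1c(O)c(-c3cccs3)nn(CCC3CC3)c1=O)N2` has not yet been measured and differs from compound 3 in one place: cyclopropyl in place of tert-butyl on a saturated chain carbon, two bonds along the chain from an aromatic nitrogen. The 3,3-dimethylbutyl group thus becomes 2-cyclopropylethyl, and the rest of the molecule stays the same.

Going by the values given here, the one measured step is a step that the two limits leave unreadable from compound 1 to compound 2 and it offers little guidance. Its size cannot be read, and it sits on an aromatic carbon rather than on this chain. The expectation therefore starts from compound 3 at > 1000 nM as a limit and assumes no step beyond the scatter in this assay for this swap. The estimate amounts to an expected step that the limit leaves unreadable from compound 3 to compound 4 in this comparison. Most likely the result will again be only a limit. For compound 4 the estimated value is 20000 nM with an expected range from 3000 nM to 60000 nM in this measurement.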

Compound 4, half-maximal cytotoxic concentration: > 33000 nM
Compound 4: only a limit was reported; the forecaster's own chance of this, stated with the estimate: 80%; middle value at least 1.6-fold (0.21 log units) from the limit.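

In this assay, going by these compounds alone, compound 3 and compound 4 are each reported only as a limit, and no step between them can be read. The compounds shown leave open the actual half-maximal cytotoxic concentration of compound 3 and of compound 4, and with it whether swapping tert-butyl for cyclopropyl changes how much compound is tolerated at all.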